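Replacing the carbonyl substituent of compound 2

The source may report more compounds than this note shows. Statements on the series, on what has been measured and on what is new or still open speak of the compounds shown alone.

In a functional assay on the whole organism (trachea) for inhibition, with Cavia porcellus as the target (a higher number here means that more compound is needed for the effect, a lower number that less compound is needed), compound 1 `O=C(O)[C@@H]1CSC(CCc2ccccc2O)N1` gives 45 mg/kg while compound 3 `COc1ccccc1OCC1N(C(=O)C[S+](C)[O-])CC[S+]1[O-]` gives 25 mg/kg and compound 2 `COc1ccccc1OCC1SCCN1C(=O)C[S+](C)[O-]` gives 10 mg/kg as the lowest of the three numbers, with its gaps to both others beyond the usual scatter. Compound 4 `CCOC(=O)C(C)(C)C(=O)N1CCSC1COc1ccccc1OC` is not yet measured and differs from compound 2 by a group of 8 heavy atoms (6 carbon, 2 oxygen; no ring) in place of a group of 4 heavy atoms (2 carbon, 1 oxygen, 1 sulfur; no ring), on a carbonyl carbon (the entering group is 1-(ethoxycarbonyl)-1-methylethyl, on a carbonyl carbon whose other neighbour is an amide-type nitrogen in a ring). No measured pair in the series isolates a change of this kind in this assay so the expectation rests on thin ground. With compound 2 at 10 mg/kg as the low end of the three numbers, a moderate rise in the number is expected rather than a further fall. The expected step is a 2.0-fold higher number from compound 2 to compound 4 (0.30 log units; within the scatter) and lies near the edge of the usual scatter. For compound 4 the estimate is 20 mg/kg with an expected range from 6 mg/kg to 60 mg/kg in this measurement.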

Compound 4, dose for half-maximal effect: 48 mg/kg
The estimate for compound 4 lay 2.4-fold (0.38 log units) below the measured number; the range from low to high includes it.
By their numbers in this assay, from the lowest: compound 2; then compounds 3, 1 and 4 (each within the scatter of the next).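

In this assay, among these compounds, the carbonyl carbon of compound 2 now gives the first single-place change that can be read, with a 4.8-fold higher number from compound 2 to compound 4 (0.68 log units; beyond the scatter) as its step. This position therefore does not tolerate every group: exchanging the small sulfur-bearing group of compound 2 for 1-(ethoxycarbonyl)-1-methylethyl gives a clear loss in this read-out. Nothing measured here bears on the cause of this step.

A single step cannot separate the contributions of the ethyl ester, the two methyl groups and the larger heavy-atom count, since all of them enter together. On these data alone, it remains open whether a carboxylic acid in place of the ethyl ester, a chain without the two methyl groups, or an amine on the carbonyl carbon would keep the number close to that of compound 2.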